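The source may hold more compounds than are shown below. What is called first, only, known or untested is meant among the compounds shown, and "the series" means these compounds.

Measured compounds:
- compound 1 `CCOc1cc(CN2CCC(NC(=O)c3cncc(C)c3)CC2)cc(OCC)c1-c1ccc(OC(F)(F)F)cc1`: "not determined" (no result reported)
- compound 2 `CCOc1cc(CN2CCC(NC(=O)c3ccc(NC(C)C)nc3)CC2)cc(OCC)c1F`: 7.84

Among the compounds with values here, in a physicochemical assay for acid dissociation, read by spectrophotometry, compound 2 gives 7.84, the only number so far, so it cannot yet be ranked against any other compound. Compound 1 has no reported result and offers no comparison, even though it carries the same 5-methylpyridin-3-yl group as the next compound.

The next compound is compound 3 `CCOc1cc(CN2CCC(NC(=O)c3cncc(C)c3)CC2)cc(OCC)c1F`, which keeps the rest of compound 2 and changes only the group on the carbonyl carbon: 5-methylpyridin-3-yl in place of 6-(isopropylamino)pyridin-3-yl on a carbonyl carbon. Within the data shown here, no step between measured compounds is available, so the size of this change in this assay has no direct precedent. Among the measured compounds shown here, the expectation therefore rests on the single anchor of compound 2 at 7.84 and on the change being confined to that one place. A slight move to a lower number is expected, but nothing beyond the usual scatter. The expected step is a number 0.14 log units lower from compound 2 to compound 3 (within the scatter). For compound 3 the estimated value is 7.7, with an expected range of 7.3 to 8.1.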

Compound 3, acid dissociation constant: 7.7
Beside the measured number, compound 3's estimate shows no gap at the digits printed; the range from low to high includes it.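

In this assay, within the data shown here, 5-methylpyridin-3-yl in place of 6-(isopropylamino)pyridin-3-yl on a carbonyl carbon gives a number 0.14 log units lower from compound 2 to compound 3 (within the scatter) as the first step that can be read. This position therefore takes a group with 7 heavy atoms and 0 hydrogen-bond donors in place of one with 10 heavy atoms and 1 hydrogen-bond donor without the read-out leaving the usual scatter, at least for this single pair with the rest of the structure held constant. No supporting measurement bears on this result, so the step stays an observation without an assigned cause.

On these data alone, whether the read-out stays level for other groups on this carbonyl carbon remains open, for example a pyridin-3-yl ring carrying a carboxylic acid, a primary amine or a longer alkyl chain. Also open, as far as these compounds go, is whether the same exchange behaves alike on a different core, since compound 1 carries 5-methylpyridin-3-yl but has no number to compare, and one pair cannot establish a trend.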